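This account rests on a few compounds, and the source may have more. Where it says the series, first, only, none or still open, it means among the compounds named here.

Compound 1, `COc1ccc2c(c1)[n+]([O-])nc(NCOCc1ccccc1)[n+]2[O-]`, gives 88500 nM in a functional assay on PC-3 cells (Homo sapiens) for cytotoxicity, read by MTT assay, with a stated time of 72 h; a lower number here means a stronger inhibitor, a higher number a weaker inhibitor.
Compound 2, `[O-][n+]1nc(NCOCc2ccccc2)[n+]([O-])c2ccccc21`, gives 11900 nM in this assay.
Compound 3, `CC(OCNc1n[n+]([O-])c2ccccc2[n+]1[O-])c1ccccc1`, gives 10700 nM in this assay.

Among these three numbers compound 2 stands second highest. Its nearest neighbour is compound 3, reached by a 1.1-fold lower number from compound 2 to compound 3 (0.05 log units; within the scatter), a step that sits within the scatter, so the two values cannot be ordered. Its furthest neighbour is compound 1, from which compound 2 is reached by a 7.4-fold lower number from compound 1 to compound 2 (0.87 log units; beyond the scatter), a modest but real step.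

Compound 4, `CCCCOCNc1n[n+]([O-])c2ccccc2[n+]1[O-]`, has not yet been measured in this assay. It differs from compound 2 in one place: propyl in place of phenyl on a saturated chain carbon bound to an oxygen on a saturated carbon.

Neither measured step probes this change directly. The step from compound 1 to compound 2 concerns a methoxy on an aromatic carbon of the shared core, not the benzyl side. The step from compound 2 to compound 3 touches the same region, a saturated chain carbon bound to an oxygen on a saturated carbon, and it was within the scatter. On that basis only a small step is expected for this assay, with no confident direction. Compound 4 is therefore expected to give about 16000 nM, within a range of 5000 nM to 50000 nM. The expected step is a 1.3-fold higher number from compound 2 to compound 4 (0.13 log units; within the scatter).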

Compound 4, half-maximal inhibitory concentration: 6010 nM
Estimate against measurement, compound 4: 2.7-fold (0.43 log units) above, and the stated range covers the measured number.
By their numbers in this assay, from the lowest: compounds 4, 3 and 2 (each within the scatter of the next); then compound 1.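

Replacing phenyl with propyl on a saturated chain carbon bound to an oxygen on a saturated carbon gives, in this assay, a 2.0-fold lower number from compound 2 to compound 4 (0.30 log units; within the scatter), so the two values cannot be ordered. The earlier compounds shown here changed this region only by adding a methyl and kept the phenyl, whereas this pair shows that the six-membered aromatic ring can give way to an open carbon chain, benzyl to butyl, without a step beyond the scatter. No measurement is available that would account for this result.

The compounds shown leave open whether the same holds for a longer chain, an amine or a carboxylic acid at this place. They also leave open whether methoxy on an aromatic carbon of the shared core would bring a step of the same size with butyl in place of benzyl as in a 7.4-fold lower number from compound 1 to compound 2 (0.87 log units; beyond the scatter).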